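A few compounds are considered here, and "the series" means these few. Any claim that something is new, unique, unknown or untested is made for them only; others in the source may bear on it.

Measured compounds:
- compound 1, `O=C1/C(=C/c2ccccc2F)CN(C(=S)SCc2cn(Cc3ccccc3Cl)nn2)C/C1=C\c1ccccc1F`: 43600 nM
- compound 2, `Cc1ccc(/C=C2\CN(Cc3cn(Cc4ccc(F)cc4)nn3)C/C(=C\c3ccc(C)cc3)C2=O)cc1`: 57200 nM

Both numbers come from a functional assay on 4T1 cells (Mus musculus) for cytotoxicity, read by MTT assay, with a stated time of 24 h; on this read-out higher numbers stand for weaker inhibition and lower numbers for stronger inhibition. Compound 1 gives 43600 nM and compound 2 gives 57200 nM. These two values lie within the usual scatter of repeated measurements, so they cannot be ranked, and compound 1 stands level with compound 2 on this evidence.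

The next compound to be tested is compound 3, `O=C1/C(=C/c2ccccc2F)CN(C(=S)SCc2cn(Cc3ccccc3F)nn2)C/C1=C\c1ccccc1F`. It differs from compound 1 at a single place: fluoro in place of chloro on an aromatic carbon. This is fluoro in place of chloro on an aromatic carbon, ortho to a large group, so 2-chlorobenzyl becomes 2-fluorobenzyl. The rest of the structure stays the same.

For the measured compounds named here, no measured pair of compounds shows what this exchange does in this assay, so the expectation rests on compound 1 alone, at 43600 nM. No change beyond the scatter is expected in either direction. The estimated step, a 1.0-fold higher number from compound 1 to compound 3 (0.01 log units; within the scatter), is expected to stay within that scatter. The expected value for compound 3 is 45000 nM, with an estimated range from 22000 nM to 90000 nM.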

Compound 3, half-maximal inhibitory concentration: 30700 nM
Compound 3: the middle estimate sits 1.5-fold (0.17 log units) above what was measured, and the stated range covers the measured number.
By their numbers in this assay, from the lowest: compounds 3, 1 and 2 (each within the scatter of the next).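

For the compounds shown here, the exchange of 2-chlorobenzyl for 2-fluorobenzyl gives the first direct reading of a single change in this assay, with the rest of the structure held the same. The result, a 1.4-fold lower number from compound 1 to compound 3 (0.15 log units; within the scatter), means that chloro and fluoro at this place, on an aromatic carbon ortho to a large group, cannot be told apart on this evidence. Nothing available here accounts for this outcome, and this one pair speaks only for this place and this exchange.

Because both groups in this pair are halogens, the compounds shown leave open whether this place responds at all to what is attached there, a question that an unsubstituted benzyl group, or one carrying a methoxy group, an amine or a carboxylic acid in place of the halogen, could begin to answer. Also open, on these data alone, is whether a much larger group at the same place, such as a phenyl ring, would keep the number level with those of compound 1 and compound 3 or move it beyond the usual scatter.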